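This account rests on a few compounds, and the source may have more. Where it says the series, first, only, none or still open, it means among the compounds named here.

Compound 1 `CCCCCCC(CCO)n1cnc2c(Cl)nc(Cl)nc21`: 12100 nM in a functional assay on HCT-116 cells (Homo sapiens) for antiproliferative activity, read by MTT assay, with a stated time of 48 h; a lower number here means a stronger inhibitor, a higher number a weaker inhibitor. Compound 2 `CCCCCCCC(CCO)n1cnc2c(Cl)nc(Cl)nc21`: 12800 nM. Compound 3 `CCCCCCCC[C@H](CCO)n1cnc2c(Cl)ncnc21`: 1120 nM.

Compound 3 stands apart from the other two; the difference between its core and the core of compound 1 is not broken down here. Compound 2 differs from compound 1 by methyl in place of hydrogen on a saturated chain carbon, seven bonds along the chain from an aromatic nitrogen, and that step, a 1.1-fold higher number from compound 1 to compound 2 (0.02 log units; within the scatter), leaves the number essentially unchanged.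

Compound 4 `CCCCCCCCC[C@H](CCO)n1cnc2c(Cl)ncnc21` is not yet measured. It differs from compound 3 by methyl in place of hydrogen on a saturated chain carbon, nine bonds along the chain from an aromatic nitrogen. Going by the values given here, this is the same kind of change as the one from compound 1 to compound 2, though the place is not the same: seven bonds along the chain there, nine bonds here. Because a 1.1-fold higher number from compound 1 to compound 2 (0.02 log units; within the scatter) stayed within the scatter, the step from compound 3 to compound 4 is expected to be small as well, a 1.1-fold higher number from compound 3 to compound 4 (0.05 log units; within the scatter). Compound 4 is therefore estimated at 1250 nM, between 600 nM and 2600 nM.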

Compound 4, half-maximal inhibitory concentration: 450 nM
Estimate against measurement, compound 4: 2.8-fold (0.44 log units) above, outside the stated range (below it).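

In this assay the added methyl gives a 2.5-fold lower number from compound 3 to compound 4 (0.40 log units; beyond the scatter) and, taken alone, this step is larger than the usual scatter, but it cannot be told apart from the same change on the other core: the same change on two cores in this assay, a 1.1-fold higher number (0.02 log units; within the scatter) from compound 1 to compound 2 and a 2.5-fold lower number (0.40 log units; beyond the scatter) from compound 3 to compound 4, 2.6-fold (0.42 log units) apart, within the scatter of two such steps. Going by these compounds alone, this shows no firm difference between the two cores, but with only one pair of steps it does not prove that the change carries over unchanged. The two steps also sit at different places, seven bonds along the chain in one and nine in the other, so any effect of the core cannot be separated from that of place.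

Going by these compounds, what a longer chain would do on the core of compound 4 remains open. So does the effect of an amine in place of the hydroxyl group.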